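Removing a methylsulfanyl group from the most potent acetal

The source may hold more compounds than are shown below. What is called first, only, known or untested is meant among the compounds shown, and "the series" means these compounds.

Measured compounds:
compound 1 `O=C(O)CC/C=C\CC1COC(c2ccccc2Cl)OC1c1cccnc1` — 759 nM
compound 2 `O=C(O)CC/C=C\CC1COC(c2ccc([N+](=O)[O-])cc2)OC1c1cccnc1` — 933 nM
compound 3 `CSc1ccc(OC(C)(C)C2OCC(C/C=C\CCC(=O)O)C(c3cccnc3)O2)c([N+](=O)[O-])c1` — 4.47 nM

In a functional assay for inhibition, with Homo sapiens as the target (a higher number here means weaker binding, a lower number tighter binding), compound 3 gives 4.47 nM, the lowest number of the three; compound 1 gives 759 nM and compound 2 gives 933 nM, both well beyond the scatter from compound 3. Compound 4 `CC(C)(Oc1ccccc1[N+](=O)[O-])C1OCC(C/C=C\CCC(=O)O)C(c2cccnc2)O1` has not yet been measured. It differs from compound 3 in one place: hydrogen in place of methylsulfanyl on an aromatic carbon, meta to a nitro group and para to a large group.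

For the measured compounds named here, only one measured step exists, a 1.2-fold higher number from compound 1 to compound 2 (0.09 log units; within the scatter), and it concerns an exchange of whole aryl groups on a saturated ring carbon, not a substituent on the aryl ring itself, so it does not bear directly on the change in hand. Going by the values given here, the data therefore give no measured step of the same kind. Given that compound 3 alone carries the methylsulfanyl group and the two compounds lacking it lie far higher, a moderate rise is expected for compound 4, with a 2.7-fold higher number from compound 3 to compound 4 (0.43 log units; beyond the scatter) as the expected step. Compound 4 is estimated at 12 nM, within 3 nM to 50 nM.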

Compound 4, dissociation constant: 11.2 nM
Beside the measured number, compound 4's estimate is 1.1-fold (0.03 log units) above it; measured number inside the range.
By their numbers in this assay, from the lowest: compound 3; then compound 4; then compounds 1 and 2 (each within the scatter of the next).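

Replacing methylsulfanyl with hydrogen on this aromatic carbon, meta to a nitro group and para to a large group, gives in this assay a measurable but limited change: a 2.5-fold higher number from compound 3 to compound 4 (0.40 log units; beyond the scatter). For the compounds shown here, this is the only measured step at a substituent on this aryl ring, and compound 4 still gives 11.2 nM without the methylsulfanyl group, so that group is not required for a value of this order. Nothing measured here accounts for the size of this step.

Going by these compounds, it remains open whether another group on this carbon, such as methoxy, chlorine or an amine, would give a lower or a higher number than hydrogen does in compound 4. The part played by the nitro group also remains open, since no compound shown replaces it with a nitrile or a hydrogen while keeping the rest of compound 4 unchanged.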